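Notes on the step from compound 3 to compound 4

The compounds below may be only part of what the source reports. "The series", "measured", "known", "first", "only" and "open" are said of these compounds alone.

In a functional assay on A549 cells (Homo sapiens) for antiproliferative activity, read by sulforhodamine B assay, with a stated time of 48 h (on this read-out higher numbers stand for weaker inhibition and lower numbers for stronger inhibition), compound 1 `COc1ccc(C=C(C(=O)/C=C/c2cccc(OC)c2OC)C(=O)/C=C/c2cccc(OC)c2OC)cc1O` gives 270 nM and compound 2 `COc1ccc(OC)c(/C=C/C(=O)C(=Cc2ccc(OC)c(OC)c2)C(=O)/C=C/c2cc(OC)ccc2OC)c1` gives 400 nM while compound 3 `COc1ccc(OC)c(/C=C/C(=O)C(=Cc2ccc(O)c(F)c2)C(=O)/C=C/c2cc(OC)ccc2OC)c1` gives 220 nM and stands within the scatter of both. Compound 4 `COc1ccc(OC)c(/C=C/C(=O)C(=Cc2ccc(OC)c(O)c2)C(=O)/C=C/c2cc(OC)ccc2OC)c1` has 3-hydroxy-4-methoxyphenyl in place of 3-fluoro-4-hydroxyphenyl on a double-bonded chain carbon bound to a double-bonded chain carbon. Among the compounds with values here, the one measured step at this place is a 1.8-fold lower number from compound 2 to compound 3 (0.26 log units; within the scatter) and it stays small. Compound 1 already carries 3-hydroxy-4-methoxyphenyl at this place, with different dimethoxyphenyl groups elsewhere, and gives 270 nM there. No change beyond the scatter is therefore expected in this assay (a 1.2-fold higher number from compound 3 to compound 4 (0.09 log units; within the scatter)). The estimate for compound 4 is 270 nM (expected range 140 nM to 520 nM).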

Compound 4, half-maximal inhibitory concentration: 390 nM
Beside the measured number, compound 4's estimate is 1.4-fold (0.16 log units) below it; the range from low to high includes it.
By their numbers in this assay, from the lowest: compounds 3, 1, 4 and 2 (each within the scatter of the next).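

Exchanging the groups at this place in this assay gives (a 1.8-fold higher number from compound 3 to compound 4 (0.25 log units; within the scatter)), so a second replacement on this ring also stays within the scatter. Hydrogen in place of methyl on an oxygen on an aromatic ring gives (a 1.0-fold lower number from compound 2 to compound 4 (0.01 log units; within the scatter)), so a hydroxy group and a methoxy group at that oxygen are not told apart here. Compound 2, compound 3 and compound 4 thus share one level in this assay.

Going by these compounds, whether an amine or a carboxylic acid on this ring would move the number beyond the scatter stays open. No evidence is at hand on what lies behind these small steps.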